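The source may report more compounds than this note shows. Statements on the series, on what has been measured and on what is new or still open speak of the compounds shown alone.

Of the compounds shown here, three sharing one core have been measured in a functional assay on HCT-116 cells (Homo sapiens) for inhibition, read by MTT assay, with a stated time of 2 days, tested at 100 uM; on this read-out lower numbers stand for less inhibition of growth and higher numbers for more inhibition of growth at the one concentration tested. Compound 1 `CNC(=O)c1cc(Oc2ccc3nc(NC(=O)c4cc(Cl)cc(Cl)c4)sc3c2)ccn1` gives 15.8%. Compound 2 `CNC(=O)c1cc(Oc2ccc3nc(NC(=O)c4cccc(F)n4)sc3c2)ccn1` gives 55.5%. Compound 3 `CNC(=O)c1cc(Oc2ccc3nc(NC(=O)Nc4ccc(Br)cc4)sc3c2)ccn1` gives 80%, the highest of the three numbers; its lead over the nearest, compound 2, is a number 24.5 percentage points higher from compound 2 to compound 3 (beyond the scatter), and over compound 1 it is a number 64.2 percentage points higher from compound 1 to compound 3 (beyond the scatter). Between compound 1 and compound 2 the step is a number 39.7 percentage points higher from compound 1 to compound 2 (beyond the scatter). All three steps exchange the group on the carbonyl carbon, and in each case moving towards the urea of compound 3 raised the number.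

Compound 4 `CNC(=O)c1cc(Oc2ccc3nc(NC(=O)Nc4ccc(Cl)cc4Cl)sc3c2)ccn1` keeps the urea of compound 3 and differs only in the ring on the amide-type nitrogen: 2,4-dichlorophenyl in place of 4-bromophenyl on an amide-type nitrogen. Among the compounds with values here, no measured step exchanges one substituted phenyl on that nitrogen for another, so none bears directly on this change. The only halogenated phenyl among the measured compounds sits on compound 1, on a carbonyl carbon rather than on a nitrogen, and says nothing about this position. The expectation is therefore a step of a number 12 percentage points lower from compound 3 to compound 4 (beyond the scatter) in this assay, that is little change beyond the scatter, with wide uncertainty. Compound 4 is estimated at 68%, between 35% and 92%.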

Compound 4, percent growth inhibition at one concentration: 93.6%
Estimate against measurement, compound 4: 25.6 percentage points below, and the stated range ends below it.
By their numbers in this assay, from the lowest: compound 1; then compound 2; then compound 3; then compound 4.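

In this assay, the ring on the amide-type nitrogen of the urea proves able to shift the number on its own: with the urea kept, 2,4-dichlorophenyl in place of 4-bromophenyl gives a number 13.6 percentage points higher from compound 3 to compound 4 (beyond the scatter), although this single swap changes both the kind of halogen and how many halogens the ring carries, so the step cannot be assigned to either alone. The earlier lead of the urea over the two amides also holds for this second urea, with a number 38.1 percentage points higher from compound 2 to compound 4 (beyond the scatter) and a number 77.8 percentage points higher from compound 1 to compound 4 (beyond the scatter), which leaves compound 4 with the highest number of the four. No other measurement bears on why this ring gives the higher number.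

From the compounds shown here alone, it remains open what a plain phenyl ring, or a ring carrying a methoxy group or a carboxylic acid instead of halogen, would give on this nitrogen. Because every number comes from one concentration, the compounds shown also leave open whether compound 4 would keep its place in the order at lower concentrations.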